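A few compounds are considered here, and "the series" means these few. Any claim that something is new, unique, unknown or untested is made for them only; others in the source may bear on it.

Compound 1 `Cn1ncc(Cl)c1-c1cc(C(=O)N[C@@H]2CN[C@H](CCCO)C[C@H]2c2ccc(Cl)c(Cl)c2)oc1Cl` was tested in a functional assay on OVCAR-8 cells (Homo sapiens) for antiproliferative activity (a higher number here means a weaker inhibitor, a lower number a stronger inhibitor), and gave 600 nM. Of the two compounds measured, compound 1 stands with the highest number. Compound 2 `Cn1ncc(Cl)c1-c1cc(C(=O)N[C@@H]2CNCC[C@H]2c2ccc(C(F)(F)F)cc2)oc1Cl` differs from compound 1 in several places at once. In this assay, going by the values given here, compound 2 gives 120 nM; no single step links these two compounds, so their two numbers can only be set side by side. Compound 3 `Cn1ncc(Cl)c1-c1cc(C(=O)N[C@@H]2CN[C@H](CCN3CCCC3)C[C@H]2c2ccc(Cl)c(Cl)c2)oc1Cl` has not yet been measured. It differs from compound 1 in one place: pyrrolidin-1-yl in place of hydroxymethyl on a saturated chain carbon, two bonds along the chain from a saturated ring carbon. The leaving group has no ring, while the entering group brings one five-membered non-aromatic ring with one hetero atom. Among the compounds with values here, no measured pair shows this change, so the size of the step is open. The change is expected to give a 2.0-fold lower number from compound 1 to compound 3 (0.30 log units; within the scatter), a step toward a lower number. For compound 3 the expected value in this assay is 300 nM, with a range from 80 nM to 1200 nM.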

Compound 3, half-maximal inhibitory concentration: 1840 nM
Compound 3: the middle estimate sits 6.1-fold (0.79 log units) below what was measured; measured number outside the range, above it.
By their numbers in this assay, from the lowest: compound 2; then compound 1; then compound 3.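

Replacing 3-hydroxypropyl with 2-(pyrrolidin-1-yl)ethyl gives a 3.1-fold higher number from compound 1 to compound 3 (0.49 log units; beyond the scatter) in this assay, a move toward weaker inhibition. Going by these compounds alone, this is the first direct reading of this position, and it shows that the group carried on this chain can change the result, at least for this one swap. No available measurement explains why the number rises.

A single step cannot separate the loss of the hydroxyl from the arrival of the pyrrolidine ring, so an open-chain dimethylamino group, a morpholine ring or a carboxylic acid at the chain end would be needed to tell these apart. Compound 2 differs from compound 1 in several places at once, so it leaves open how much the chain itself matters compared with a shorter or longer chain.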